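This account rests on a few compounds, and the source may have more. Where it says the series, first, only, none or still open, it means among the compounds named here.

Compound 1 `CCC(/C=C(\COC(C)=O)C(=O)c1ccc(OC)cc1)CC` is the reference point for this set. In a functional assay on MCF7 cells (Homo sapiens) for inhibition, read by XTT assay, with a stated time of 48 h (on this read-out higher numbers stand for weaker inhibition and lower numbers for stronger inhibition), compound 1 gives 13700 nM. Compound 2 `CCC(/C=C(\COC(=O)c1ccccc1)C(=O)c1ccc(OC)cc1)CC` differs from compound 1 in a single place, (phenyl in place of methyl on a carbonyl carbon), and in this assay compound 2 gives 28000 nM. The step of a 2.0-fold higher number from compound 1 to compound 2 (0.31 log units; beyond the scatter) is modest but lies outside the ordinary scatter of repeated measurements, so in this pair the larger group went with weaker inhibition.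

Compound 3 `C=C(C(=O)c1ccc(OC)cc1)C(OC(C)=O)c1ccccc1F` carries a different core; how its core differs from that of compound 1 is not broken down here. In this assay compound 3 gives 18000 nM. That value and the value of compound 1 sit within the usual scatter of each other, and the same holds for the value of compound 3 against that of compound 2, so those two pairs support no ranking.

Compound 4 `C=C(C(=O)c1ccc(OC)cc1)C(OC(=O)c1ccccc1)c1ccccc1F` has not yet been measured. It differs from compound 3 by phenyl in place of methyl on a carbonyl carbon, the same change that turns compound 1 into compound 2, made at the same place. Going by the values given here, with only one precedent for this change, the expectation for compound 4 rests on the single step of a 2.0-fold higher number from compound 1 to compound 2 (0.31 log units; beyond the scatter) and on the value of compound 3, 18000 nM. The step expected from compound 3 to compound 4 is therefore a 2.0-fold higher number from compound 3 to compound 4 (0.30 log units; within the scatter), a shift of about the same size and direction as before. On that basis compound 4 is estimated to give 36000 nM in this assay, with a plausible range from 18000 nM to 72000 nM.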

Compound 4, half-maximal inhibitory concentration: 34200 nM
Compound 4: middle estimate off by 1.1-fold (0.02 log units), on the high side, and the stated range covers the measured number.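

On the core of compound 3, replacing methyl with phenyl on a carbonyl carbon (acetoxy to benzoyloxy) gives, in this assay, a 1.9-fold higher number from compound 3 to compound 4 (0.28 log units; within the scatter), and this step taken alone is too small to count as a real difference. Its meaning comes from setting it beside the same replacement on the core of compound 1, and the two steps cannot be told apart: the same change on two cores in this assay, a 2.0-fold higher number (0.31 log units; beyond the scatter) from compound 1 to compound 2 and a 1.9-fold higher number (0.28 log units; within the scatter) from compound 3 to compound 4, 1.1-fold (0.03 log units) apart, within the scatter of two such steps. Going by these compounds alone, this fits the idea that the replacement carries over between these two cores with much the same effect on the read-out, but it rests on only two pairs in a single cell assay, so it shows neither that the match would hold on a third core nor why the numbers behave this way.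

The compounds shown leave open what an acyl group other than acetyl or benzoyl would do at this place, such as a longer chain like butanoyl, a benzoyl carrying an amine or a carboxylic acid, or an amide in place of the ester. They also leave open whether the agreement between the two steps would persist in other cell lines.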